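The source may hold more compounds than are shown below. What is called first, only, known or untested is meant among the compounds shown, and "the series" means these compounds.

Measured compounds:
Compound 1, `Cc1ccc(S(=O)(=O)N[C@@H](CCC(=O)N2CCC3(CC2)CCN(c2ccncc2)CC3)C(=O)O)cc1`: in a functional assay for inhibition, with Homo sapiens as the target (a lower number here means a stronger inhibitor, a higher number a weaker inhibitor), compound 1 gives 78 nM.
Compound 2, `Cc1noc(C)c1S(=O)(=O)N[C@@H](CNC(=O)N1CCC2(CC1)CCN(c1ccncc1)CC2)C(=O)O`: in this assay compound 2 gives 39 nM.
Compound 3, `O=C(O)CCCCC(=O)N1CCC2(CC1)CCN(c1ccncc1)CC2`: in this assay compound 3 gives 4540 nM.

All three compounds share the same core. Compound 1 holds the second highest of the three numbers. Its number and that of compound 2 lie within the usual scatter of each other, so no order between them can be read. Compound 3 sits far higher than compound 1, well beyond the scatter, and is the weakest inhibitor of the three.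

Compound 4, `CCCCOC(=O)N[C@@H](CCC(=O)N1CCC2(CC1)CCN(c1ccncc1)CC2)C(=O)O`, differs from compound 1 in one place: butoxycarbonyl in place of (4-methylphenyl)sulfonyl on an amine nitrogen. For the measured compounds named here, no measured pair shows this exact change, so its effect must be judged from the structures alone. The group that enters is smaller and has no ring, yet it keeps a substituent on that amine nitrogen, whereas compound 3, which lacks this whole part of the molecule, gives a far higher number. Compound 4 is therefore expected to remain a clear inhibitor but a somewhat weaker one than compound 1, with an expected step of a 2.6-fold higher number from compound 1 to compound 4 (0.41 log units; beyond the scatter) that is modest and close to the edge of the scatter. The estimate for compound 4 in this assay is 200 nM, with a likely range from 60 nM to 700 nM.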

Compound 4, half-maximal inhibitory concentration: 722 nM
Estimate against measurement, compound 4: 3.6-fold (0.56 log units) below; measured number outside the range, above it.
By their numbers in this assay, from the lowest: compounds 2 and 1 (each within the scatter of the next); then compound 4; then compound 3.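

Among the compounds shown, this is the only pair that differs in one place: butoxycarbonyl in place of (4-methylphenyl)sulfonyl on an amine nitrogen brings, in this assay, a 9.3-fold higher number from compound 1 to compound 4 (0.97 log units; beyond the scatter). This shows that the number responds to the group on this nitrogen: the swap removes the six-membered aromatic ring and the sulfur, leaves the count of hydrogen-bond acceptors unchanged, and still gives a weaker inhibitor. Nothing available explains why the number rises, so the step stands as an observation only.

The swap changes several things at once, the ring, the sulfur and the open chain, so this one pair cannot show which of them accounts for the step. Butylsulfonyl, which keeps the sulfur and has the open chain, and benzyloxycarbonyl, which keeps the carbonyl of compound 4 and brings back an aromatic ring, are the kinds of groups that could pull these features apart.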